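This account rests on a few compounds, and the source may have more. Where it says the series, first, only, none or still open, it means among the compounds named here.

Compound 3 `Cn1c(COc2cccc(C(=O)O)c2)nc2ccc(Oc3cccc(Cl)n3)cc21` gives 7.7 ug/mL in a physicochemical assay for solubility, read by HPLC, measured as thermodynamic solubility, with a stated time of 4 h, at pH 6.8 (a higher number here means a more soluble compound, a lower number a less soluble compound), the second highest of the three numbers. Compound 2 `Cc1ccc(Oc2ccc3nc(COc4cccc(C(=O)O)c4)n(C)c3n2)cc1C` gives 16 ug/mL, and compound 1 `Cc1ccc(Oc2ccc3nc(COc4cccc(C(=O)O)c4)n(C)c3n2)c(C)c1` gives 0.9 ug/mL. Compound 4 `Cc1ccc(C)c(Oc2ccc3nc(COc4cccc(C(=O)O)c4)n(C)c3c2)n1` differs from compound 3 in one place: 3,6-dimethylpyridin-2-yl in place of 6-chloropyridin-2-yl on an oxygen on an aromatic ring. For the measured compounds named here, the only measured step, an 18-fold higher number from compound 1 to compound 2 (1.25 log units; beyond the scatter), concerns a rearrangement of two methyl groups on the aryl ether and bears only loosely on this change, in which two methyls replace a chlorine on the pyridine ring. Given that precedent, a step of uncertain direction is expected, a 1.9-fold lower number from compound 3 to compound 4 (0.28 log units; within the scatter), with a wide range. Compound 4 is therefore estimated at 4 ug/mL, between 1 ug/mL and 15 ug/mL.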

Compound 4, solubility: 85 ug/mL
Compound 4: the middle estimate sits 21-fold (1.33 log units) below what was measured; the whole stated range lies below it.
By their numbers in this assay, from the lowest: compound 1; then compound 3; then compound 2; then compound 4.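

With 3,6-dimethylpyridin-2-yl in place of 6-chloropyridin-2-yl on an oxygen on an aromatic ring, this assay shows an 11-fold higher number from compound 3 to compound 4 (1.04 log units; beyond the scatter). For the compounds shown here, the earlier step involved only dimethylphenyl groups, so this is the first sign that exchanging the groups on a pyridine ring here can also give a large upward step. No measurement at hand accounts for this step. As far as these compounds go, compound 3 and compound 4 differ in both chlorine and methyl groups, so which of these changes carries the step remains open. Also open, from the compounds shown here alone, is how an amine or a methoxy group on the pyridine ring would read.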